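Swapping 3-chlorophenyl for (pyridin-2-yl)oxy on the saturated ring

The source may report more compounds than this note shows. Statements on the series, on what has been measured and on what is new or still open speak of the compounds shown alone.

Compound 3 (`O=C(Nc1cc(-c2ccccn2)n[nH]1)N1CCC(c2cccc(Cl)c2)CC1`) has no exact reading in an ADME assay on cells (Peritoneal macrophage cell, Mus musculus) for cytotoxicity, read by fluorescence and resazurin assay, with a stated time of 3 days; a higher number here means that more compound is tolerated, a lower number that less compound is tolerated. Compound 3 gives only a limit, > 22000 nM. Compound 1 (`O=C(Nc1cc(-c2ccccn2)n[nH]1)N1CCC(c2cccc(F)c2)CC1`) also gives only a limit, > 45000 nM. Compound 2 (`O=C(Nc1cc(-c2ccccn2)n[nH]1)N1CCC(Oc2ccccc2)CC1`) likewise gives a limit, > 40000 nM. In compound 4 (`O=C(Nc1cc(-c2ccccn2)n[nH]1)N1CCC(Oc2ccccn2)CC1`), (pyridin-2-yl)oxy stands in place of 3-chlorophenyl on a saturated ring carbon: (pyridin-2-yl)oxy in place of 3-chlorophenyl on a saturated ring carbon. The measured evidence consists of a step that the two limits leave unreadable from compound 2 to compound 3, a step that the two limits leave unreadable from compound 1 to compound 2 and a step that the two limits leave unreadable from compound 1 to compound 3. None of these supplies a size or direction, so no clear shift is expected, and the estimated change is a step that the limit leaves unreadable from compound 3 to compound 4. For compound 4 the expected value is 40000 nM, within an estimated range of 15000 nM to 100000 nM.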

Compound 4, half-maximal cytotoxic concentration: > 64000 nM
Compound 4 was reported as a limit; the forecaster's own chance of this, stated with the estimate: 75%; middle value at least 1.6-fold (0.20 log units) from the limit.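

Compound 4 gives only a limit in this assay, as do compound 1, compound 2 and compound 3, so none of its steps to these compounds can be read. The compounds shown leave open whether changing the group on the saturated ring carbon alters the tolerated concentration at all.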